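The source may hold more compounds than are shown below. What is called first, only, known or untested is meant among the compounds shown, and "the series" means these compounds.

Compound 1 `Nc1nc2c(s1)CC[C@H]2C(=O)Nc1ccc(C[C@@H]2CC[C@H]([C@H](O)c3ccccc3)N2)cc1` is the reference. In an ADME assay on MDCK-II cells (Canis lupus familiaris) for permeability (on this read-out higher numbers stand for higher permeability and lower numbers for lower permeability), compound 1 gives 5 10^-6 cm/s, the lowest of the two numbers shown. Compound 2 `Cc1nc2c(s1)CC[C@H]2C(=O)Nc1ccc(C[C@@H]2CC[C@H]([C@H](O)c3cccnc3)N2)cc1` gives 17 10^-6 cm/s. Compound 3 `Nc1nc2c(s1)CC[C@H]2C(=O)Nc1ccc(C[C@@H]2CC[C@H]([C@H](O)c3cccnc3)N2)cc1` gives < 1 10^-6 cm/s, which is the limit of < 1 10^-6 cm/s in this assay, at which 1 of the 3 values shown sits, rather than a number. The two measured steps concern other changes: an at least 5.0-fold lower number from compound 1 to compound 3 (0.69 log units; beyond the scatter), and an at least 17-fold lower number from compound 2 to compound 3 (1.23 log units; beyond the scatter). Compound 4 `Nc1nc2c(s1)CCC[C@H]2C(=O)Nc1ccc(C[C@@H]2CC[C@H]([C@H](O)c3ccccc3)N2)cc1` differs from compound 1 elsewhere: a group of 10 heavy atoms (7 carbon, 2 nitrogen, 1 sulfur; one five-membered aromatic ring with 2 hetero atoms, one six-membered non-aromatic ring of carbon only) in place of a group of 9 heavy atoms (6 carbon, 2 nitrogen, 1 sulfur; one five-membered non-aromatic ring of carbon only, one five-membered aromatic ring with 2 hetero atoms), on a carbonyl carbon. Within the data shown here, no measured step touches this kind of change, so there is no basis for a direction. The expected step is therefore one that stays within the usual scatter, no change at the digits printed from compound 1 to compound 4 (within the scatter). Compound 4 is accordingly estimated at 5 10^-6 cm/s, with a range from 2.5 10^-6 cm/s to 10 10^-6 cm/s.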

Compound 4, apparent permeability: 5 10^-6 cm/s
For compound 4 middle estimate and measured number coincide at the digits printed; the range from low to high includes it.
By their numbers in this assay, from the lowest: compounds 1 and 4 (each within the scatter of the next); then compound 2. At a limit, below all of these: compound 3.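

Going from the five-membered to the six-membered carbon-only ring, on the carbonyl carbon, gives no change at the digits printed from compound 1 to compound 4 (within the scatter) in this assay. Unlike the earlier swaps of phenyl for pyridin-3-yl and of methyl for amino, this change leaves the number unmoved, at least in this one pair. Nothing shown speaks to the reason for this result. Going by these compounds, whether the larger ring behaves the same way with pyridin-3-yl in place of phenyl remains open. So does the outcome with a seven-membered carbon-only ring at this place.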